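This account rests on a few compounds, and the source may have more. Where it says the series, first, only, none or still open, it means among the compounds named here.

Measured so far:
compound 1, `CC(C)C(=O)N1CC2CC(C1)N2`, 16000 nM
compound 2, `O=C([C@H]1C[C@H]1F)N1CC2CC(C1)N2`, 62 nM

Among the compounds with values here, compound 2 holds the lowest of the two numbers in an assay on CHO cells for agonist activity at Neuronal acetylcholine receptor; alpha3/alpha6/beta2/beta3 (Homo sapiens), read by FLIPR and calcium flux; a higher number here means that more compound is needed for the effect, a lower number that less compound is needed; its only neighbour is compound 1, and the step between them, a 260-fold lower number from compound 1 to compound 2 (2.41 log units; beyond the scatter), lies beyond the scatter. Within the data shown here, that step, the replacement of isopropyl by 2-fluorocyclopropyl on the carbonyl carbon, is the only measured change in the set.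

Compound 3, `O=C([C@@H]1C[C@@H]1F)N1CC2CC(C1)N2`, differs from compound 2 in this way: the two compounds have the same atoms and bonds; at least one stereo element is drawn with a configuration in one of them and without one in the other: 2 of 4 stereo elements differ; a stereocentre at a saturated ring carbon is drawn R in compound 2 and S in compound 3; a stereocentre at a saturated ring carbon is drawn R in compound 2 and S in compound 3. Among the measured compounds shown here, no measured step concerns a change of drawn configuration; the step from compound 1 to compound 2 exchanges the whole group on the carbonyl carbon and does not bear on which configuration the 2-fluorocyclopropyl carries. For the measured compounds named here, the data therefore give no direction for this step. Compounds that are mirror images in part can give very different numbers or nearly the same, so a wide range is the honest expectation, centred somewhat above compound 2. Compound 3 is expected to give 250 nM in this assay, between 50 nM and 2500 nM, which means an expected step of a 4.0-fold higher number from compound 2 to compound 3 (0.61 log units; beyond the scatter).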

Compound 3, half-maximal effective concentration: 88 nM
Compound 3: middle estimate off by 2.8-fold (0.45 log units), on the high side; the range from low to high includes it.
By their numbers in this assay, from the lowest: compounds 2 and 3 (each within the scatter of the next); then compound 1.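

In this assay, inverting both drawn ring stereocentres of the 2-fluorocyclopropyl group gives a 1.4-fold higher number from compound 2 to compound 3 (0.15 log units; within the scatter), so the assay does not separate these two drawn forms, a point that compound 2 alone could not show. The large step away from isopropyl is therefore not confined to one drawn form of the group: alongside a 260-fold lower number from compound 1 to compound 2 (2.41 log units; beyond the scatter) there now stands a 180-fold lower number from compound 1 to compound 3 (2.26 log units; beyond the scatter), and both steps are large. Reading compounds 2 and 3 as a clean comparison of configurations carries one reservation, which limits how far their closeness can be taken: the fact that one of compounds 2 and 3 is drawn with a defined configuration and the other without, at the place where they differ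

The compounds shown leave open whether the step from isopropyl belongs to the fluorine or to the three-membered ring itself, a question that a plain cyclopropyl group or a 2-methylcyclopropyl group on the carbonyl carbon would address. Also open, as far as these compounds go, is how the other pairing of configurations at the two ring stereocentres of the 2-fluorocyclopropyl group would read in this assay.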